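The compounds below may be only part of what the source reports. "The series", "measured", "known", "first", "only" and "open" are said of these compounds alone.

In a functional assay on the whole organism for inhibition, with Mus musculus as the target (on this read-out higher numbers stand for an effect only at larger amounts of compound and lower numbers for an effect already at smaller amounts), compound 1 `CCNC(=O)Nc1cccc2c1CN(C)CC2c1ccccc1` gives 80 mg/kg. Compound 2 `CCCNC(=O)Nc1cccc2c1CN(C)CC2c1ccccc1` reads > 80 mg/kg, which is a limit. Among the compounds with values here, compound 3 `CCCCNC(=O)Nc1cccc2c1CN(C)CC2c1ccccc1` gives about 40 mg/kg, and its only numerical comparison is a 2.0-fold lower number from compound 1 to compound 3 (0.30 log units; within the scatter). The limit also leaves an at least 2.0-fold lower number from compound 2 to compound 3 (0.30 log units; that floor lies within the scatter) with only a floor, while a number no lower from compound 1 to compound 2 (the limit leaves the size open) has no readable size. Compound 4 `CCOC(=O)Nc1cccc2c1CN(C)CC2c1ccccc1` differs from compound 3 by ethoxy in place of butylamino on a carbonyl carbon, with ethoxy in place of butylamino on a carbonyl carbon. No measured step makes this exchange, so the chain steps are only weak guides, and none of them is shown beyond the scatter. No shift beyond the scatter is therefore expected in this assay, and the expected change is a 1.3-fold higher number from compound 3 to compound 4 (0.10 log units; within the scatter). For compound 4 the estimate is 50 mg/kg, with an expected range of 20 mg/kg to 110 mg/kg.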

Compound 4, dose for half-maximal effect: 3.2 mg/kg
Beside the measured number, compound 4's estimate is 16-fold (1.19 log units) above it; measured number below the stated range.
By their numbers in this assay, from the lowest: compound 4; then compounds 3 and 1 (each within the scatter of the next).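

In this assay, the carbonyl carbon proves a sensitive position: ethoxy in place of an alkylamino group gives a 13-fold lower number from compound 3 to compound 4 (1.10 log units; beyond the scatter), whereas no chain step among the earlier compounds is shown beyond the scatter. The ethyl chain stays the same in a 25-fold lower number from compound 1 to compound 4 (1.40 log units; beyond the scatter), so this large step comes with the exchange of amino for oxy linkage alone. A third step reads an at least 25-fold lower number from compound 2 to compound 4 (1.39 log units; beyond the scatter), a floor only, resting on a limit: the limit of > 80 mg/kg in this assay, at which 1 of the 4 values shown sits.

On these data alone, whether methoxy, butoxy or a longer alkoxy chain on this carbonyl carbon keeps the low number stays open. So does the outcome with a plain alkyl group there.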